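A few compounds are considered here, and "the series" means these few. Any claim that something is new, unique, unknown or untested is made for them only; others in the source may bear on it.

Of the compounds shown here, two with a shared core have been tested in an ADME assay on RAW264.7 cells (Mus musculus) for cytotoxicity, read by MTT assay; a lower number here means a stronger inhibitor, a higher number a weaker inhibitor. In this assay, compound 1 `CC(C)CCOc1cccc(O)c1C(=O)/C=C/c1ccc(O)cc1` gives > 30000 nM, which is a limit of the assay and not a number. Compound 2 `CCCCCCOc1cccc(O)c1C(=O)/C=C/c1ccc(O)cc1` gives > 30000 nM, which is also a limit. Compound 2 therefore has no exact place on the scale, and the only reference point is the limit of > 30000 nM in this assay, at which 2 of the 2 values shown sit.

Compound 3 `CCCCCCCCOc1cccc(O)c1C(=O)/C=C/c1ccc(O)cc1` differs from compound 2 in one place: ethyl in place of hydrogen on a saturated chain carbon, six bonds along the chain from an oxygen on an aromatic ring. Among the compounds with values here, the one measured step that bears on this change is a step that the two limits leave unreadable from compound 1 to compound 2. It also alters the chain on the oxygen, but both of its ends are limits, so it offers no size to carry forward. With no measured size to build on, the expectation in this assay is for no shift beyond the usual scatter and for no particular direction, although a real fall in the number cannot be excluded. The estimated step is a number no higher from compound 2 to compound 3 (the limit leaves the size open). For compound 3 the expected value is 30000 nM, with an estimated range from 12000 nM to 60000 nM.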

Compound 3, half-maximal inhibitory concentration: > 30000 nM
Compound 3 ended at the assay's limit; the forecaster's own chance of this, stated with the estimate: 70%; the middle value lies on the limit itself.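

No step can be read between compound 1, compound 2 and compound 3 in this assay, because each ends at a limit of the assay and not at a number: the limit of > 30000 nM in this assay, at which 3 of the 3 values shown sit. The compounds shown leave open where each one truly lies on the scale and whether the different chains on the oxygen change the number at all.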